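Methoxy on the aromatic ring of a weak lactam

The source may report more compounds than this note shows. Statements on the series, on what has been measured and on what is new or still open speak of the compounds shown alone.

Compound 3 `C=C1CC(c2ccccc2)N(C)C1=O` gives 553000 nM in a functional assay on NALM-6 cells (Homo sapiens) for cytotoxicity, read by MTT assay, with a stated time of 48 h (on this read-out higher numbers stand for weaker inhibition and lower numbers for stronger inhibition), the highest of the two single numbers known for this assay. The nearest is compound 1 `C=C1CC(c2cccc3ccccc23)OC1=O`, which in this assay gives 3860 nM, a gap well beyond the usual scatter of repeated measurements. Compound 2 `C=C1C(=O)OC(c2ccccc2)C1C` has been run more than once in this assay, giving 5420 nM; 7910 nM (2 entries), and so carries no single number (the several entries of compound 2 in this assay, 5420 nM; 7910 nM (2 entries)).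

Compound 4 `C=C1CC(c2ccc(OC)cc2)N(C)C1=O` differs from compound 3 by methoxy in place of hydrogen on an aromatic carbon. Among the compounds with values here, no measured pair shows this change on its own, so its size cannot be read from the numbers in hand. The account therefore rests on compound 3 alone: the methoxy group is expected to move the number by a step within the scatter in this assay, with no direction that can be stated with confidence, which is the step of a 1.4-fold lower number from compound 3 to compound 4 (0.14 log units; within the scatter). Compound 4 is accordingly estimated at 400000 nM, with a range from 100000 nM to 1500000 nM.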

Compound 4, half-maximal inhibitory concentration: 523000 nM
Compound 4: the middle estimate sits 1.3-fold (0.12 log units) below what was measured; the range from low to high includes it.
By their numbers in this assay, from the lowest: compound 1; then compounds 4 and 3 (each within the scatter of the next).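

Methoxy in place of hydrogen on an aromatic carbon, para to a group of 8 heavy atoms, comes out in this assay as a 1.1-fold lower number from compound 3 to compound 4 (0.02 log units; within the scatter). The earlier compounds shown here held no pair with this change, so this is its first direct reading: on this core, at this position, the methoxy group does not move the number beyond the scatter. Nothing in hand offers a reason for this result.

The compounds shown leave open whether an amine, a carboxylic acid or a longer chain such as ethoxy at the same position would also leave the number within the scatter. They also leave open whether methoxy would give so small a step on the core of compound 1, or at another carbon of the aromatic ring.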